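The compounds below may be only part of what the source reports. "The series", "measured", "known", "first", "only" and "open" are said of these compounds alone.

Working notes on the series.

Compound 1 `FC(F)(F)c1ccc(CSc2nc(Nc3ccccc3C(F)(F)F)c3ccccc3n2)cc1` is the anchor. In a functional assay on HGC-27 cells (Homo sapiens) for cytotoxicity, read by MTT assay, with a stated time of 72 h (a lower number here means a stronger inhibitor, a higher number a weaker inhibitor), compound 1 gives only a limit, > 50000 nM; that is the limit of > 50000 nM in this assay, at which 1 of the 3 values shown sits. Compound 2 `O=[N+]([O-])c1ccc(Nc2nc(SCc3ccc(C(F)(F)F)cc3)nc3ccccc23)cc1` gives 16600 nM in this assay. Compound 3 `Cc1ccc(Nc2nc(SCc3ccc(C(F)(F)F)cc3)nc3ccccc23)cc1` gives 34600 nM in this assay. The step of an at least 3.0-fold lower number from compound 1 to compound 2 (0.47 log units; beyond the scatter) and the step of an at least 1.4-fold lower number from compound 1 to compound 3 (0.15 log units; that floor lies within the scatter) both start from the limit of compound 1, so only the first is clearly beyond the scatter; between the two para-substituted anilines the step of a 2.1-fold higher number from compound 2 to compound 3 (0.32 log units; beyond the scatter) is modest.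

Compound 4 `COc1ccc(Nc2nc(SCc3ccc(C(F)(F)F)cc3)nc3ccccc23)cc1` is not yet measured. The change from compound 1 is 4-methoxyphenyl in place of 2-(trifluoromethyl)phenyl on a nitrogen on an aromatic ring. Both measured steps from compound 1 bear on it, since each also replaces the 2-(trifluoromethyl)phenyl with a para-substituted phenyl on that nitrogen; 4-methoxyphenyl is closest in kind to 4-methylphenyl, so the reading of compound 3 is the nearer guide. A step of about an at least 1.6-fold lower number from compound 1 to compound 4 (0.22 log units; that floor lies within the scatter) is therefore expected, toward a lower number but possibly within the scatter of the limit. Compound 4 is estimated at 30000 nM in this assay, in the range 12000 nM to 80000 nM.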

Compound 4, half-maximal inhibitory concentration: 23500 nM
Beside the measured number, compound 4's estimate is 1.3-fold (0.11 log units) above it; the range from low to high includes it.
By their numbers in this assay, from the lowest: compounds 2, 4 and 3 (each within the scatter of the next, the first and the last beyond it). At a limit, above all of these: compound 1.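

Working from the limit of compound 1, the change to 4-methoxyphenyl on the nitrogen gives a second step that clears the scatter (an at least 2.1-fold lower number from compound 1 to compound 4 (0.32 log units; beyond the scatter)) in this assay, joining the step to compound 2, whereas the floor of the step to compound 3 stays within it. Compound 1 stands only as a limit, so the size of that step is a floor: the limit of > 50000 nM in this assay, at which 1 of the 4 values shown sits. On the aromatic carbon, methoxy separates from neither methyl (a 1.5-fold lower number from compound 3 to compound 4 (0.17 log units; within the scatter)) nor nitro (a 1.4-fold higher number from compound 2 to compound 4 (0.15 log units; within the scatter)), so it adds an intermediate reading without a new distinction.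

The compounds shown leave open how the series responds to an amine or a carboxylic acid on that aromatic carbon. They also leave open what a cyclohexyl or a longer alkyl chain would do in place of the aromatic ring on the nitrogen.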